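Working notes on the step from compound 2 to compound 3

The source may hold more compounds than are shown below. What is called first, only, known or untested is meant among the compounds shown, and "the series" means these compounds.

Two compounds carry numbers in an ADME assay on the whole organism (Rattus norvegicus) for metabolic stability; on this read-out higher numbers stand for a longer-lived compound and lower numbers for a shorter-lived compound. Compound 1 `COc1ccc(C(=O)C2=C(O)C(=O)N(c3ccc(-c4ccon4)cc3)C2C2CCCCC2)cn1` gives 1.4 h. Compound 2 `CCC(CC)C1C(C(=O)c2ccc(OC)cc2)=C(O)C(=O)N1c1ccc(-c2ccon2)cc1` gives 4.2 h, the higher of the two, with compound 1 sitting lower by a gap that goes beyond the scatter. Among the measured compounds shown here, no measured pair differs in one place only, so no single-change step is on record. Compound 3 `COc1ccc(C(=O)C2=C(O)C(=O)N(c3ccc(-c4ccon4)cc3)C2c2ccccc2OC)cc1` differs from compound 2 by 2-methoxyphenyl in place of pentan-3-yl on a saturated ring carbon. For the measured compounds named here, for this change no measured precedent exists. The step from compound 2 to compound 3 is expected to be a moderate drop, a 1.9-fold lower number from compound 2 to compound 3 (0.28 log units; within the scatter). For compound 3 the estimate is 2.2 h, with a range from 0.8 h to 5.5 h.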

Compound 3, half-life: 0.5 h
For compound 3 the middle estimate is 4.4-fold (0.64 log units) above the measured one; the measured number lies below the stated range.
By their numbers in this assay, from the lowest: compound 3; then compound 1; then compound 2.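

In this assay, among the compounds shown here, the first single-change reading at this position is an 8.4-fold lower number from compound 2 to compound 3 (0.92 log units; beyond the scatter) when 2-methoxyphenyl replaces pentan-3-yl on the saturated ring carbon next to the ring nitrogen. The half-life therefore responds to the group on this carbon, and in this one pair the aromatic ring goes with the shorter-lived compound. Nothing measured accounts for the drop.

The compounds shown leave open whether the drop follows the ring itself or its methoxy group. An unsubstituted phenyl or a longer chain carrying an amine on this carbon also remains an open case.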